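Secondary amides on the shared core: from azetidine to oxetane

The source may hold more compounds than are shown below. What is called first, only, known or untested is meant among the compounds shown, and "the series" means these compounds.

Three measured compounds share one core, a piperidine carboxamide bearing a bis-sulfonylated aryl group, and differ only in the amide substituent. Compound 1 `CCN(CC)S(=O)(=O)c1ccc(S(=O)(=O)N2CCC[C@@H](C(=O)N(C)C(C)C)C2)cc1` carries an isopropyl(methyl)amino group and gives 1400 nM in a functional assay on MIA PaCa-2 cells (Homo sapiens) for inhibition, read by MTT assay, with a stated time of 3 days; on this read-out lower numbers stand for stronger inhibition and higher numbers for weaker inhibition. Compound 2 `CCN(CC)C(=O)[C@@H]1CCCN(S(=O)(=O)c2ccc(S(=O)(=O)N(CC)CC)cc2)C1` carries a diethylamino group and gives 700 nM in this assay; the change a 2.0-fold lower number from compound 1 to compound 2 (0.30 log units; within the scatter) is within the scatter. Compound 3 `CCN1CC(NC(=O)[C@@H]2CCCN(S(=O)(=O)c3ccc(S(=O)(=O)N(CC)CC)cc3)C2)C1` carries a (1-ethylazetidin-3-yl)amino group. In this assay compound 3 reaches only the limit > 10000 nM, a limit of the assay and not a number, as described by the limit of > 10000 nM in this assay, at which 1 of the 3 values shown sits. The steps to it are clear: an at least 7.1-fold higher number from compound 1 to compound 3 (0.85 log units; beyond the scatter) and an at least 14-fold higher number from compound 2 to compound 3 (1.15 log units; beyond the scatter), so compound 3 stands weakest of the three.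

Compound 4 `CCN(CC)S(=O)(=O)c1ccc(S(=O)(=O)N2CCC[C@@H](C(=O)NC3COC3)C2)cc1` is not yet measured. It differs from compound 3 by oxetan-3-yl in place of 1-ethylazetidin-3-yl on an amide-type nitrogen. Both compounds 3 and 4 are thus secondary amides bearing a four-membered ring, while compounds 1 and 2 are tertiary amides. Going by the values given here, no measured step separates the two four-membered rings, so the only guide is that compound 3 sits at the limit. From the limit of compound 3, the expected step is an at least 1.1-fold lower number from compound 3 to compound 4 (0.04 log units; that floor lies within the scatter), and the number is expected to stay near the limit. Compound 4 is therefore estimated at 9000 nM, with a range from 2500 nM to 30000 nM.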

Compound 4, half-maximal inhibitory concentration: 900 nM
Estimate against measurement, compound 4: 10-fold (1.00 log units) above, and the stated range ends above it.
By their numbers in this assay, from the lowest: compounds 2, 4 and 1 (each within the scatter of the next). At a limit, above all of these: compound 3.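

In this assay, oxetan-3-yl in place of 1-ethylazetidin-3-yl on the amide-type nitrogen gives an at least 11-fold lower number from compound 3 to compound 4 (1.04 log units; beyond the scatter), so being a secondary amide bearing a four-membered ring does not by itself set compound 3 apart from the tertiary amides. The two remaining steps, a 1.3-fold higher number from compound 2 to compound 4 (0.11 log units; within the scatter) and a 1.6-fold lower number from compound 1 to compound 4 (0.19 log units; within the scatter), show that this secondary amide cannot be told apart from the two tertiary amides, which means that among these four compounds the weak result goes with the 1-ethylazetidin-3-yl group and not with the amide type. Compound 3 stands at a limit and not at a number, so the full size of its step stays unknown: the limit of > 10000 nM in this assay, at which 1 of the 4 values shown sits.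

The compounds shown leave open whether the weak result follows the ring nitrogen itself or the ethyl group on it, a question that a cyclobutyl group or an azetidin-3-yl group carrying acetyl in place of ethyl would address. They also leave open how an open-chain secondary amide such as isopropylamino, or a larger ring such as tetrahydropyran-4-yl, would behave on this amide nitrogen.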